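This account rests on a few compounds, and the source may have more. Where it says the series, first, only, none or still open, it means among the compounds named here.

Working notes on the series. Compound 1 `Fc1cc(Cl)ccc1-c1ccc(Cn2nnc3ccccc32)cn1` and compound 2 `Fc1cc(Cl)ccc1-c1ccc(Cn2nnc3c(F)cccc32)cn1` share a core, and compound 2 differs from compound 1 by fluoro in place of hydrogen on an aromatic carbon. In an ADME assay on microsomes from liver (Homo sapiens) for metabolic stability, tested at 2.5 uM (a higher number here means faster removal of the compound, a lower number slower removal), compound 1 gives 0.01 mL/min/g, while compound 2 gives 0.1 mL/min/g, which is a 10-fold higher number from compound 1 to compound 2 (1.00 log units; beyond the scatter). Compound 3 `Brc1cccc2c1nnn2Cc1ccccc1` sits on a different core; the difference between the two cores is not broken down here. In this assay compound 3 gives 4.7 mL/min/g, the highest of the three numbers. Compound 4 `Fc1cccc(Cn2nnc3c(Br)cccc32)c1` is not yet measured and differs from compound 3 by fluoro in place of hydrogen on an aromatic carbon, the same kind of change as between compound 1 and compound 2, though the place differs: there the fluoro sits ortho to a fused ring and meta to a fused ring, here meta to a large group on a ring that is not fused. With a single precedent for this change, and that on another core, the expected step from compound 3 to compound 4 in this assay is smaller, about a 1.2-fold higher number from compound 3 to compound 4 (0.07 log units; within the scatter); compound 4 is expected to give 5.5 mL/min/g, between 2.5 mL/min/g and 12 mL/min/g.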

Compound 4, intrinsic clearance in a liver preparation (reported as CLH), per the amount of preparation that the assay uses: 1.8 mL/min/g
Compound 4: the middle estimate sits 3.1-fold (0.49 log units) above what was measured, outside the stated range (below it).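

In this assay the new step is a 2.6-fold lower number from compound 3 to compound 4 (0.42 log units; beyond the scatter), opposite in direction to the earlier one. Set side by side, the two steps show that the result of this change on one core does not carry over to the other: the same change on two cores in this assay, a 10-fold higher number (1.00 log units; beyond the scatter) from compound 1 to compound 2 and a 2.6-fold lower number (0.42 log units; beyond the scatter) from compound 3 to compound 4, 26-fold (1.42 log units) apart, beyond the scatter of two such steps

With a single pair on each core and the fluoro at a different place in each, the data do not show whether the core or the place accounts for the gap, nor how the change would behave on any further core. Open, as far as these compounds go, is how fluoro at other aromatic carbons on the core of compound 3 would read in this assay. Also open, from the compounds shown here alone, is whether a methoxy or an amine at the place of that fluoro would follow compound 4.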